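The source may hold more compounds than are shown below. What is called first, only, known or untested is meant among the compounds shown, and "the series" means these compounds.

Compound 1 `CCCCCCOc1ccc(C(=O)/C=C/c2c(/C=C/c3ccc(OC)cc3)cc(OC)cc2OC)cc1`: 16.2 ug/mL
Compound 2 `COc1ccc(/C=C/c2cc(OC)cc(OC)c2/C=C/C(=O)c2ccc(C(F)(F)F)cc2)cc1`: 18.7 ug/mL

In a functional assay on HepG2 cells (Homo sapiens) for antiproliferative activity, read by MTT assay, with a stated time of 48 h (a higher number here means a weaker inhibitor, a lower number a stronger inhibitor), compound 2 gives 18.7 ug/mL. Within the data shown here, with only two measured compounds, it cannot be told apart from compound 1, since their numbers lie within the scatter of each other.

Compound 3 `COc1ccc(/C=C/c2cc(OC)cc(OC)c2/C=C/C(=O)c2ccc(N)cc2)cc1` keeps the core of compound 2 and alters one group: amino in place of trifluoromethyl on an aromatic carbon. This puts amino in place of trifluoromethyl on an aromatic carbon, para to a large group.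

Among the measured compounds shown here, only one measured step bears on this change. It also swaps the group at this place, and it is a 1.2-fold higher number from compound 1 to compound 2 (0.06 log units; within the scatter). That step stayed within the scatter, so replacing hexyloxy with trifluoromethyl left this assay with no readable difference. For the measured compounds named here, no measured compound carries an amino group, however, so the evidence is thin and the range must stay wide.

The expected change is no larger than the scatter, and no direction can be claimed with confidence. The estimated step is a 1.2-fold lower number from compound 2 to compound 3 (0.10 log units; within the scatter). Compound 3 is expected to give 15 ug/mL, with an estimated range of 6 ug/mL to 35 ug/mL.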

Compound 3, half-maximal inhibitory concentration: 7.5 ug/mL
The estimate for compound 3 lay 2.0-fold (0.30 log units) above the measured number, and the stated range covers the measured number.
By their numbers in this assay, from the lowest: compound 3; then compounds 1 and 2 (each within the scatter of the next).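

In this assay this place on the aromatic ring, para to a large group, now shows a readable difference: amino in place of trifluoromethyl gives a 2.5-fold lower number from compound 2 to compound 3 (0.40 log units; beyond the scatter), and amino in place of hexyloxy gives a 2.2-fold lower number from compound 1 to compound 3 (0.33 log units; beyond the scatter). The earlier pair could not be told apart, so trifluoromethyl and hexyloxy alone gave no sign that the group here matters, whereas amino separates from both, although each step is modest. The data shown offer no measured explanation for this difference.

On these data alone, it remains open whether the lower number is particular to amino or would also appear with another group at this place, such as hydroxyl, dimethylamino or acetamido. As far as these compounds go, all three compounds also carry the same methoxy groups on the shared core, and what those groups contribute to the numbers in this assay remains unknown.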